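Replacing a cyclohexenyl acyl group with a bicyclic one

This account rests on a few compounds, and the source may have more. Where it says the series, first, only, none or still open, it means among the compounds named here.

Measured compounds:
- compound 1, `CC1CC=C(C(=O)N(c2cc(C#CC(C)(C)C)sc2C(=O)O)C(C)C)CC1`: > 20000 nM
- compound 2, `CC(C)(C)C#Cc1cc(N(C(=O)[C@H]2CC[C@H](C)CC2)[C@H]2CC[C@H](OC3CCOC3)CC2)c(C(=O)O)s1`: > 20000 nM
- compound 3, `CC(C)(C)C#Cc1cc(N(C(=O)[C@H]2CC[C@H](C)CC2)[C@H]2CC[C@H](Oc3ccc4nccn4n3)CC2)c(C(=O)O)s1`: > 20000 nM

In an ADME assay on MT4 cells (Homo sapiens) for cytotoxicity, with a stated time of 5 days (a lower number here means that less compound is tolerated, a higher number that more compound is tolerated), compound 1 gives > 20000 nM, which is a limit of the assay rather than a number. Compound 2 likewise sits at a limit. Compound 3 also sits at a limit. Compound 1 therefore cannot be placed above or below the other two; all three share the same position, as the limit of > 20000 nM in this assay, at which 3 of the 3 values shown sit, records. Among the compounds with values here, the one step that can be followed, a step that the two limits leave unreadable from compound 2 to compound 3, is unreadable between two limits, and it alters a different part of the molecule from the change considered here.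

Compound 4 is `CC(C)N(C(=O)[C@H]1[C@@H]2CCCC[C@@H]21)c1cc(C#CC(C)(C)C)sc1C(=O)O`. It differs from compound 1 by a group of 7 heavy atoms (7 carbon; one three-membered non-aromatic ring of carbon only, one six-membered non-aromatic ring of carbon only) in place of a group of 7 heavy atoms (7 carbon; one six-membered non-aromatic ring of carbon only), on a carbonyl carbon.

Within the data shown here, no measured step bears on this change, and every value shown is a limit, so there is no basis for expecting any readable step beyond the scatter in this assay. Compound 4 is therefore expected to sit again at the limit, with an estimate of 30000 nM spanning 15000 nM to 60000 nM, and the expected step that the limit leaves unreadable from compound 1 to compound 4 is taken as none.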

Compound 4, half-maximal cytotoxic concentration: > 20000 nM
Compound 4: no number, only a limit (the forecaster's own chance of this, stated with the estimate: 85%); the middle value does not contradict the limit.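

In this assay, within the data shown here, compound 4 gives > 20000 nM, a limit of the assay rather than a number, so no step from compound 1 to compound 4 can be read. What stays open is the concentration at which any of these compounds harms the cells, because all of them share one position: the limit of > 20000 nM in this assay, at which 4 of the 4 values shown sit.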